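Pyridazinone amides: cross-check of an untested aryl combination

The compounds below may be only part of what the source reports. "The series", "measured", "known", "first", "only" and "open" are said of these compounds alone.

Measured so far in a functional assay on MCF7 cells (Homo sapiens) for cytotoxicity, read by MTT assay, with a stated time of 72 h; on this read-out lower numbers stand for stronger inhibition and higher numbers for weaker inhibition:
- compound 1 `Cc1cc(=O)n(-c2ccc(Br)cc2F)nc1C(=O)Nc1ccc(Oc2ncnc3[nH]ccc23)c(F)c1`: 26600 nM
- compound 2 `Cc1cc(=O)n(-c2ccc(Br)cc2F)nc1C(=O)Nc1ccc(Oc2ncnc3c2ccn3C)cc1`: 27700 nM
- compound 3 `Cc1cc(=O)n(-c2ccccc2OC(F)(F)F)nc1C(=O)Nc1ccc(Oc2ncnc3c2ccn3C)c(F)c1`: > 60000 nM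

Compound 3 stands at the bottom of what is shown: its value in this assay is a limit, not a number, and it is the one value sitting at the limit of > 60000 nM in this assay, at which 1 of the 3 values shown sits. Compounds 1 and 2 both give numbers, and these two numbers lie within the usual scatter of each other, so nothing separates them.

Compound 4 `Cc1cc(=O)n(-c2ccc(Br)cc2F)nc1C(=O)Nc1ccc(Oc2ncnc3c2ccn3C)c(F)c1` differs from compound 3 in a single place: 4-bromo-2-fluorophenyl in place of 2-(trifluoromethoxy)phenyl on an aromatic nitrogen. This is the same 4-bromo-2-fluorophenyl that compounds 1 and 2 carry, and compound 4 otherwise keeps the rest of compound 3 unchanged. Among the measured compounds shown here, no step between measured compounds covers this exact exchange, so no measured size of step can be quoted for it.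

Compound 4 is expected to land near the numbers of compound 1 at 26600 nM and compound 2 at 27700 nM, since both carry the entering group. Compound 4 is therefore estimated at 28000 nM in this assay, in the range 12000 nM to 65000 nM. The step from compound 3 expected by this estimate is an at least 2.1-fold lower number from compound 3 to compound 4 (0.33 log units; beyond the scatter), a move from a limit to a number rather than a step of known size.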

Compound 4, half-maximal inhibitory concentration: > 60000 nM
Compound 4: only a limit was reported (the forecaster's own chance of this, stated with the estimate: 25%); middle value at least 2.1-fold (0.33 log units) from the limit.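

In this assay the value of compound 4 is a limit, > 60000 nM, and compound 3 stands at the same limit, so the step between them cannot be read: the limit of > 60000 nM in this assay, at which 2 of the 4 values shown sit.

With 4-bromo-2-fluorophenyl on the aromatic nitrogen held constant, fluoro in place of hydrogen on an aromatic carbon gives an at least 2.1-fold higher number from compound 2 to compound 4 (0.33 log units; beyond the scatter), and methyl in place of hydrogen on an aromatic nitrogen gives an at least 2.2-fold higher number from compound 1 to compound 4 (0.35 log units; beyond the scatter). Compound 1 lacks the methyl and compound 2 lacks the fluoro, and each gives a number, whereas compound 4 carries both and reaches only a limit, so 4-bromo-2-fluorophenyl alone does not secure a number.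

Going by these compounds, how far the true values of compound 3 and compound 4 lie beyond the limit remains open. Also open, on these data alone, is whether an aminoethyl chain in place of the methyl on the aromatic nitrogen would restore a number alongside the fluoro.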